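Compound 3 to compound 4: exchanging the side group

This account rests on a few compounds, and the source may have more. Where it says the series, first, only, none or still open, it means among the compounds named here.

compound 1 `N#Cc1ccccc1C1OCC(C/C=C\CCC(=O)O)C(c2cccnc2)O1`: 245 nM
compound 2 `O=C(O)CC/C=C\CC1COC(c2ccsc2)OC1c1cccnc1`: 1580 nM
compound 3 `CC(C)(C)c1ccc(OC(C)(C)C2OCC(C/C=C\CCC(=O)O)C(c3cccnc3)O2)cc1`: 1910 nM

In a functional assay for inhibition, with Homo sapiens as the target (on this read-out lower numbers stand for tighter binding and higher numbers for weaker binding), compound 3 sits at the weak end of this small set: its number lies within the usual scatter of that of compound 2, while compound 1 gives a clearly lower number. Compound 4 `Cc1ccc(SC(C)(C)C2OCC(C/C=C\CCC(=O)O)C(c3cccnc3)O2)c([N+](=O)[O-])c1` differs from compound 3 by a group of 11 heavy atoms (7 carbon, 1 nitrogen, 2 oxygen, 1 sulfur; one six-membered aromatic ring of carbon only) in place of a group of 11 heavy atoms (10 carbon, 1 oxygen; one six-membered aromatic ring of carbon only), on a saturated chain carbon bound to two saturated chain carbons and a saturated ring carbon. Within the data shown here, the only measured step, a 6.4-fold higher number from compound 1 to compound 2 (0.81 log units; beyond the scatter), alters the group on the saturated ring carbon, not the side group changed here, so it offers no direct guide. With nothing bearing on this change, no shift beyond the scatter is expected in this assay. Compound 4 is therefore estimated at 1900 nM, with a range from 600 nM to 6000 nM. The expected step is a 1.0-fold lower number from compound 3 to compound 4 (0.00 log units; within the scatter).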

Compound 4, dissociation constant: 158 nM
Compound 4: middle estimate off by 12-fold (1.08 log units), on the high side; the measured number lies below the stated range.
By their numbers in this assay, from the lowest: compounds 4 and 1 (each within the scatter of the next); then compounds 2 and 3 (each within the scatter of the next).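

In this assay, replacing 4-(tert-butyl)phenoxy with the sulfur- and nitrogen-containing group on this saturated chain carbon gives a 12-fold lower number from compound 3 to compound 4 (1.08 log units; beyond the scatter), even though both groups have the same number of heavy atoms. Among these compounds, the earlier step changed only the group on a saturated ring carbon, so this is the first sign that the side group at this place can shift the number beyond the scatter. No available evidence explains the shift.

Several features change together, so the shift cannot be assigned to the sulfur, the nitro group or the methyl group. From the compounds shown here alone, how a plain phenylthio group would read in this assay also remains open.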